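Swapping benzylamino for hydroxy on compound 3

A few compounds are considered here, and "the series" means these few. Any claim that something is new, unique, unknown or untested is made for them only; others in the source may bear on it.

Measured in an ADME assay on J774.1 cells (Mus musculus) for cytotoxicity, read by resazurin assay, with a stated time of 48 h; a lower number here means a stronger inhibitor, a higher number a weaker inhibitor:
Compound 1 `CCCCn1cc(C(=O)O)c(=O)c2cc(F)c(Cl)cc21`: > 100000 nM (a limit of the assay)
Compound 2 `CCCCn1cc(C(=O)O)c(=O)c2cc(F)c(N3CCC(C(N)=O)CC3)cc21`: > 100000 nM (a limit of the assay)
Compound 3 `CCCCn1cc(C(=O)NCc2ccccc2)c(=O)c2cc(F)c(N3CCCCC3)cc21`: 47800 nM

Within the data shown here, compound 3 gives 47800 nM, the only true number in this small set. The other two entries are limits. The step to follow leads to compound 4 `CCCCn1cc(C(=O)O)c(=O)c2cc(F)c(N3CCCCC3)cc21`, and its structural change is hydroxy in place of benzylamino on a carbonyl carbon. In words, hydroxy takes the place of benzylamino on a carbonyl carbon, which, cut one bond further out, reads benzylcarbamoyl to carboxy.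

Among the measured compounds shown here, no measured step shows this change directly. For the measured compounds named here, the one measured step, a step that the two limits leave unreadable from compound 1 to compound 2, concerns a different place and gives no size to carry over. The better guide is the limit of > 100000 nM in this assay, at which 2 of the 3 values shown sit. The carboxy group that compound 4 gains is already on compound 2, which gives > 100000 nM, again a limit. The same group is on compound 1, which gives > 100000 nM, also a limit.

A move towards a weaker number is therefore expected in this assay, though its size remains uncertain. The expected change is a 2.1-fold higher number from compound 3 to compound 4 (0.32 log units; beyond the scatter), and the assay may well report only a limit. For compound 4 the estimate is 100000 nM, with an expected range of 50000 nM to 200000 nM.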

Compound 4, half-maximal inhibitory concentration: 93000 nM
For compound 4 the middle estimate is 1.1-fold (0.03 log units) above the measured one; the measured number falls inside the stated range.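

In this assay, among these compounds, this position now has a readable pair, which the earlier compounds could not supply: a 1.9-fold higher number from compound 3 to compound 4 (0.29 log units; within the scatter). Replacing benzylamino with hydroxy on this carbonyl carbon removes the six-membered aromatic ring, yet the step stays within the usual scatter, so this pair shows no clear difference between the benzylcarbamoyl and carboxy groups. Compound 4 also gives a true number for a compound carrying carboxy, and its steps to the two compounds with limits, an at least 1.0-fold lower number from compound 2 to compound 4 (0.03 log units; that floor lies within the scatter) and an at least 1.0-fold lower number from compound 1 to compound 4 (0.03 log units; that floor lies within the scatter), have floors that lie within the scatter, so they show no clear separation: the limit of > 100000 nM in this assay, at which 2 of the 4 values shown sit.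

The compounds shown leave open whether a different group on this carbonyl carbon, such as methoxy or a small amine like methylamino, would give a value in this assay clearly apart from those of compound 3 and compound 4. They also leave open how a longer chain than butyl on the ring nitrogen of the shared core would read when paired with compound 4.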